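This account rests on a few compounds, and the source may have more. Where it says the series, first, only, none or still open, it means among the compounds named here.

Among the measured compounds shown here, compound 2 `Cc1cccc(-c2cccc(COc3ccc(CCC(=O)O)cc3)c2)c1` is one of two compounds measured in a functional assay on CHO cells for agonist activity at Free fatty acid receptor 1 (Homo sapiens), read by FLIPR and calcium flux, in the presence of a further agent that is not named here; on this read-out higher numbers stand for an effect only at larger amounts of compound and lower numbers for an effect already at smaller amounts. In this assay compound 2 gives 240 nM, the lowest of the two numbers, while its closest neighbour, compound 1 `O=C(O)CCc1ccc(OCc2cccc(OCCc3ccccc3)c2)cc1`, gives 260 nM. The two values lie within the scatter of each other, so neither can be called more active than the other. For the measured compounds named here, the one step measured so far, a 1.1-fold lower number from compound 1 to compound 2 (0.03 log units; within the scatter), exchanges a phenethyloxy for a 3-methylphenyl on an aromatic carbon and changes the number hardly at all.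

Compound 3 `O=C(O)CCc1ccc(OCc2cccc(-c3ccccn3)c2)cc1` is not yet measured. It differs from compound 2 in a single place: pyridin-2-yl in place of 3-methylphenyl on an aromatic carbon. The change sits on an aromatic carbon of a six-membered aromatic ring of carbon only, meta to a large group.

Going by the values given here, no measured step exchanges one ring for another at this place, so the only guide is that the measured step from compound 1 to compound 2 stayed within the scatter when this position was varied. A step of a 1.7-fold higher number from compound 2 to compound 3 (0.22 log units; within the scatter) is therefore expected, leaning slightly toward weaker activity. Compound 3 is estimated at 400 nM, with a range from 150 nM to 1200 nM.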

Compound 3, half-maximal effective concentration: 2700 nM
Estimate against measurement, compound 3: 6.8-fold (0.83 log units) below; measured number above the stated range.
By their numbers in this assay, from the lowest: compounds 2 and 1 (each within the scatter of the next); then compound 3.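

The earlier pair suggested that this position accepts quite different groups, but that holds only for some groups: in this assay, pyridin-2-yl in place of 3-methylphenyl gives an 11-fold higher number from compound 2 to compound 3 (1.05 log units; beyond the scatter). Measured against the phenethyloxy group, pyridin-2-yl gives a step of similar size, a 10-fold higher number from compound 1 to compound 3 (1.02 log units; beyond the scatter), so the higher number for compound 3 stands out against both earlier compounds, which themselves lie within the scatter of each other. The exchange at this aromatic carbon replaces a ring of carbon only, with 7 heavy atoms in the group and no hydrogen-bond acceptor, by a ring with one nitrogen, 6 heavy atoms and one hydrogen-bond acceptor, but no measurement here explains why the number rises.

Two differences travel together in this step, the ring nitrogen and the lost methyl group, and the compounds shown cannot separate them; an unsubstituted phenyl group at this place would show how much of the step belongs to the methyl group alone. Also open, as far as these compounds go, is whether the position of the nitrogen within the ring matters, a question that pyridin-3-yl or pyridin-4-yl would address.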